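This account rests on a few compounds, and the source may have more. Where it says the series, first, only, none or still open, it means among the compounds named here.

Series notes. Compound 1 `CCCSc1nc(Cl)c2c(n1)N(Cc1ccccc1)C(C(=O)N1CCN(Cc3ccccc3)CC1)N2` gives 57300 nM in a functional assay on PC-3 cells (Homo sapiens) for antiproliferative activity, read by MTT assay, with a stated time of 72 h; on this read-out higher numbers stand for weaker inhibition and lower numbers for stronger inhibition. Compound 2 `CCCSc1nc(Cl)c2c(n1)N(Cc1ccccc1)C(C(=O)NCCC1=CCc3ccccc31)N2` reaches only the limit of this assay, reported as > 64000 nM, which is a limit and not a number. Compound 3 `CCCSc1nc(Cl)c2c(n1)N(CCNC(=O)OC(C)(C)C)C(C(=O)N1CCN(C)CC1)N2` likewise stops at the limit, returning > 64000 nM in this assay. On the numbers shown, compound 2 therefore sits at the weak end, together with compound 3, at the limit of > 64000 nM in this assay, at which 2 of the 3 values shown sit. Compound 1 alone returns a measured value, and that value is itself weak. Compound 4 `CCCSc1nc(Cl)c2c(n1)N(Cc1ccccc1)C(C(=O)Nc1ccccc1)N2` remains to be tested. Relative to compound 2 it carries a group of 6 heavy atoms (6 carbon; one six-membered aromatic ring of carbon only) in place of a group of 11 heavy atoms (11 carbon; one five-membered non-aromatic ring of carbon only, one six-membered aromatic ring of carbon only), on an amide-type nitrogen. For the measured compounds named here, no pair of measured compounds differing in one place exists in this set, hence no step size can be read off; all three measured compounds report weak or no inhibition, and the expectation is that compound 4 behaves alike. Compound 4 is estimated at 60000 nM in this assay, with a range from 20000 nM to 150000 nM. The expected step is an at least 1.0-fold lower number from compound 2 to compound 4 (0.02 log units; that floor lies within the scatter), that is, nothing beyond the scatter, with a fair chance that only a limit is reported again.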

Compound 4, half-maximal inhibitory concentration: > 64000 nM
Compound 4 ended at the assay's limit; the forecaster's own chance of this, stated with the estimate: 55%; at least 1.0-fold (0.02 log units) between middle value and limit.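

In this assay compound 4 gives > 64000 nM as a limit and not a number. Compound 2 also stops at a limit, so no step can be read for phenyl on the amide-type nitrogen: the limit of > 64000 nM in this assay, at which 3 of the 4 values shown sit.
Going by these compounds, how the group on this nitrogen bears on inhibition in this assay stays open.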